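Benzyloxy variation at the aryl ether of the diamine series

A few compounds are considered here, and "the series" means these few. Any claim that something is new, unique, unknown or untested is made for them only; others in the source may bear on it.

Measured in a functional assay on PC-3 cells (Homo sapiens) for cytotoxicity, read by sulforhodamine B assay; a lower number here means a stronger inhibitor of growth, a higher number a weaker inhibitor of growth:
compound 1 `COc1cccc(OC)c1OCCNCCOc1ccccc1OCc1cccc(Cl)c1` gives 20400 nM
compound 2 `COc1cccc(OC)c1OCCNCCOc1ccccc1OCc1ccccc1C` gives 33900 nM
compound 3 `COc1cccc(OC)c1OCCNCCOc1ccccc1OCc1cccc([N+](=O)[O-])c1` gives 38900 nM

Compound 2 sits second highest of the three numbers; its nearest neighbour is reached by a 1.1-fold higher number from compound 2 to compound 3 (0.06 log units; within the scatter), the furthest by a 1.7-fold higher number from compound 1 to compound 2 (0.22 log units; within the scatter), so all three lie within the scatter of one another. Compound 4 `COc1cccc(OC)c1OCCNCCOc1ccccc1OCc1ccc([N+](=O)[O-])cc1` differs from compound 2 by 4-nitrophenyl in place of 2-methylphenyl on a saturated chain carbon bound to an oxygen on an aromatic ring. Among the measured compounds shown here, two measured steps bear on this: a 1.1-fold higher number from compound 2 to compound 3 (0.06 log units; within the scatter), which also swaps the 2-methylphenyl for a nitrophenyl, and a 1.9-fold higher number from compound 1 to compound 3 (0.28 log units; within the scatter), nitro in place of chloro; neither moved the number beyond the scatter. The expected step is therefore a 1.1-fold higher number from compound 2 to compound 4 (0.05 log units; within the scatter), no change beyond the scatter. Compound 4 is estimated at 38000 nM, with a range of 15000 nM to 95000 nM.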

Compound 4, concentration for total growth inhibition: 43600 nM
Compound 4: middle estimate off by 1.1-fold (0.06 log units), on the low side, within the range that was stated.
By their numbers in this assay, from the lowest: compounds 1, 2, 3 and 4 (each within the scatter of the next, the first and the last beyond it).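

In this assay 4-nitrophenyl in place of 3-nitrophenyl gives a 1.1-fold higher number from compound 3 to compound 4 (0.05 log units; within the scatter) and 4-nitrophenyl in place of 2-methylphenyl gives a 1.3-fold higher number from compound 2 to compound 4 (0.11 log units; within the scatter) so neither replacement registers. Against 3-chlorophenyl, 4-nitrophenyl gives a 2.1-fold higher number from compound 1 to compound 4 (0.33 log units; beyond the scatter) as the only step beyond the scatter at this position, and a modest one. Nothing at hand gives a reason for that step.

On these data alone, whether an amine or a carboxylic acid on the benzyl ring would move the number further stays open. So does whether a longer chain in place of the benzyl carbon would shift it.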